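The source may hold more compounds than are shown below. What is called first, only, known or untested is meant among the compounds shown, and "the series" means these compounds.

Measured so far in a functional assay on HL-60 cells (Homo sapiens) for antiproliferative activity, read by MTT assay, with a stated time of 72 h; a lower number here means a stronger inhibitor of growth, a higher number a weaker inhibitor of growth:

compound 1, `CCOC(=O)N1CCN(/[N+]([O-])=N/Oc2cc(O/N=[N+](\[O-])N(C)C)c([N+](=O)[O-])cc2[N+](=O)[O-])CC1`: 2000 nM
compound 2, `CCN(CC)/[N+]([O-])=N/Oc1cc(O/N=[N+](\[O-])N(C)C)c([N+](=O)[O-])cc1[N+](=O)[O-]`: 2300 nM
compound 3, `CCOC(=O)N1CCN(/[N+]([O-])=N/Oc2cc(O/N=[N+](\[O-])N3CCN(C(=O)N(CC)CC)CC3)c([N+](=O)[O-])cc2[N+](=O)[O-])CC1`: 3000 nM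

All three values lie close together, and none of the steps between them reaches beyond the usual scatter, so no order among compound 1, compound 2 and compound 3 can be read from these numbers.

Compound 1 and compound 2 differ in one place only: diethylamino in place of 4-(ethoxycarbonyl)piperazin-1-yl on a double-bonded nitrogen. The step that this change made is a 1.2-fold higher number from compound 1 to compound 2 (0.06 log units; within the scatter).

Compound 3 shares the diethylamino-bearing carbamate motif with compound 1 but differs from it in the core; the difference between the two cores is not broken down here.

Compound 4, `CCN(CC)C(=O)N1CCN(/[N+]([O-])=N/Oc2cc(O/N=[N+](\[O-])N(CC)CC)c([N+](=O)[O-])cc2[N+](=O)[O-])CC1`, is not yet measured in this assay. It arises from compound 3 by the same change that turned compound 1 into compound 2: diethylamino in place of 4-(ethoxycarbonyl)piperazin-1-yl on a double-bonded nitrogen. The two places are described in identical words, so this is the same change on a different core.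

The expected step from compound 3 to compound 4 is a 1.2-fold higher number from compound 3 to compound 4 (0.07 log units; within the scatter), a small step, because the same change on the other core gave a 1.2-fold higher number from compound 1 to compound 2 (0.06 log units; within the scatter). Among the measured compounds shown here, only one prior instance of the change exists, so the expectation carries a wide range.

Compound 4 is expected to give about 3500 nM in this assay. The likely range for compound 4 runs from 1500 nM to 8000 nM.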

Compound 4, concentration for total growth inhibition: > 10000 nM
Compound 4 ended at the assay's limit; the forecaster's own chance of this, stated with the estimate: 5%; at least 2.8-fold (0.45 log units) between middle value and limit.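

In this assay compound 4 gives > 10000 nM, which is a limit of the assay and not a number: the limit of > 10000 nM in this assay, at which 1 of the 4 values shown sits.

Diethylamino in place of 4-(ethoxycarbonyl)piperazin-1-yl gives an at least 3.3-fold higher number from compound 3 to compound 4 (0.52 log units; beyond the scatter), so the size of this step did not carry over from one core to the other: the same change on two cores in this assay, a 1.2-fold higher number (0.06 log units; within the scatter) from compound 1 to compound 2 and an at least 3.3-fold higher number (0.52 log units; beyond the scatter) from compound 3 to compound 4, at least 2.8-fold (0.46 log units) apart, beyond the scatter of two such steps

The pair of steps shows that, in this series, the step seen on the core of compound 1 cannot be taken as the step on the core of compound 3, but it does not show the true size of the second step, why the two differ, or how the change behaves on any further core.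

Still open, on these data alone, is whether the larger step belongs to diethylamino itself or to the particular core of compound 3. A pyrrolidin-1-yl or morpholin-4-yl group in the same place on both cores would show whether the two cores keep differing in this way.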